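Nitro for methyl on the triazole aryl group

A few compounds are considered here, and "the series" means these few. Any claim that something is new, unique, unknown or untested is made for them only; others in the source may bear on it.

In a functional assay on A549 cells (Homo sapiens) for antiproliferative activity, read by MTT assay, with a stated time of 48 h (on this read-out lower numbers stand for stronger inhibition and higher numbers for weaker inhibition), the three measured compounds share a terpenoid ester core. Compound 1 `C/C(=C\CC/C(C)=C/CC[C@@H]1[C@@]2(C)CCC(=O)C(C)(C)[C@H]2CC[C@@]1(C)O)CC/C=C(\C)C(=O)OCc1cn(-c2ccccc2C)nn1` returns only a limit, > 150000 nM, so its true value is not known. Compound 2 `C#CCOC(=O)/C(C)=C/CC/C(C)=C/CC/C(C)=C/CC[C@@H]1[C@@]2(C)CCC(=O)C(C)(C)[C@H]2CC[C@@]1(C)O` gives 45100 nM, and compound 3 `C/C(=C\CC/C(C)=C/CC[C@@H]1[C@@]2(C)CCC(=O)C(C)(C)[C@H]2CC[C@@]1(C)O)CC/C=C(\C)C(=O)OCc1cn(C[C@@H]2O[C@H](n3ccc(=O)[nH]c3=O)[C@H]3OC(C)(C)O[C@H]32)nn1` gives 15300 nM. Going by the values given here, the single one-place step, an at least 3.3-fold lower number from compound 1 to compound 2 (0.52 log units; beyond the scatter), lies beyond the scatter, but it removes the whole triazole rather than altering its aryl group. The unmeasured compound 4 `C/C(=C\CC/C(C)=C/CC[C@@H]1[C@@]2(C)CCC(=O)C(C)(C)[C@H]2CC[C@@]1(C)O)CC/C=C(\C)C(=O)OCc1cn(-c2ccc([N+](=O)[O-])cc2)nn1` differs from compound 1 by 4-nitrophenyl in place of 2-methylphenyl on an aromatic nitrogen. Among the compounds with values here, no measured step alters the aryl substituent on the triazole, so the account has no direct precedent for this change; it only shows that compound 1, with the 2-methylphenyl triazole, sits at the limit (the limit of > 150000 nM in this assay, at which 1 of the 3 values shown sits). Compound 4 is therefore expected to stay weak, with an estimated value of 120000 nM (range 40000 nM to 300000 nM). That estimate means a step of an at least 1.2-fold lower number from compound 1 to compound 4 (0.09 log units; that floor lies within the scatter), which is uncertain since compound 1 is known only as a limit.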

Compound 4, half-maximal inhibitory concentration: > 150000 nM
Compound 4: only a limit was reported; the forecaster's own chance of this, stated with the estimate: 50%; middle value at least 1.2-fold (0.09 log units) away from the limit.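

In this assay compound 4 gives > 150000 nM, a limit and not a number. Compound 1 is also known only as a limit, so no step can be read between compound 1 and compound 4: the limit of > 150000 nM in this assay, at which 2 of the 4 values shown sit. The compounds shown leave open whether 4-nitrophenyl and 2-methylphenyl differ at all in their effect on antiproliferative activity.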